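The source may report more compounds than this note shows. Statements on the series, on what has been measured and on what is new or still open speak of the compounds shown alone.

Measured compounds: compound 1 `C[C@@H](O[C@H]1CN2C(=O)C=C(c3ccccc3)CC2[C@@H]1c1ccc(F)cc1)c1cc(C(F)(F)F)cc(C(F)(F)F)c1` gives 89.5 nM in an assay on CHO cells for displacement of a labelled ligand from Substance-P receptor (Homo sapiens), in the presence of a further agent that is not named here; a higher number here means a weaker inhibitor, a lower number a stronger inhibitor; compound 2 `Cc1cc(C2=CC(=O)N3C[C@H](O[C@H](C)c4cc(C(F)(F)F)cc(C(F)(F)F)c4)[C@@H](c4ccc(F)cc4)C3C2)ccn1` gives 34 nM; compound 3 `C[C@@H](O[C@H]1CN2C(=O)C=C(C3=CCC(O)CC3)CC2[C@@H]1c1ccc(F)cc1)c1cc(C(F)(F)F)cc(C(F)(F)F)c1` gives 13 nM.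

Compound 1 stands at the highest number of the three, the others lying beyond the scatter below it.

Compound 4 `C[C@@H](O[C@H]1CN2C(=O)C=C(C3CCOCC3)CC2[C@@H]1c1ccc(F)cc1)c1cc(C(F)(F)F)cc(C(F)(F)F)c1` is unmeasured; it differs from compound 1 in one place: oxan-4-yl in place of phenyl on a double-bonded ring carbon.

The two steps from compound 1 bear on this: a 2.6-fold lower number from compound 1 to compound 2 (0.42 log units; beyond the scatter) and a 6.9-fold lower number from compound 1 to compound 3 (0.84 log units; beyond the scatter). Both exchanges of the phenyl on the double-bonded ring carbon gave a lower number, the ring that carries an oxygen giving the larger drop. An oxan-4-yl in that place is therefore expected to give a modest lowering, and the step is estimated as a 3.0-fold lower number from compound 1 to compound 4 (0.47 log units; beyond the scatter). Compound 4 is estimated at 30 nM, within 10 nM to 90 nM.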

Compound 4, half-maximal inhibitory concentration: 3.2 nM
Compound 4: middle estimate off by 9.4-fold (0.97 log units), on the high side; measured number outside the range, below it.
By their numbers in this assay, from the lowest: compound 4; then compound 3; then compound 2; then compound 1.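

Within the data shown here, at the double-bonded ring carbon, oxan-4-yl gives the lowest number so far in this assay, well clear of phenyl (a 28-fold lower number from compound 1 to compound 4 (1.45 log units; beyond the scatter)) and of 2-methylpyridin-4-yl (an 11-fold lower number from compound 2 to compound 4 (1.03 log units; beyond the scatter)). It also improves on 4-hydroxycyclohex-1-en-1-yl (a 4.1-fold lower number from compound 3 to compound 4 (0.61 log units; beyond the scatter)), so an aromatic ring and a hydroxy group are both dispensable at this position. No measurement available here explains the size of these steps.

Open, on these data alone, is whether the ring oxygen itself matters, which a plain cyclohexyl or a piperidin-4-yl amine in the same place would test. Also open, as far as these compounds go, is how a carboxylic acid on this ring would fare.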